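The source may report more compounds than this note shows. Statements on the series, on what has been measured and on what is new or still open speak of the compounds shown alone.

In an ADME assay on HEK293 cells (Homo sapiens) for cytotoxicity, read by CCK-8 assay, with a stated time of 48 h (on this read-out lower numbers stand for stronger inhibition and higher numbers for weaker inhibition), compound 1 `COc1ccc(/C=C\c2cc(OC)c(OC)c(OC)c2)cc1OCc1ccc(C=O)cc1` gives 46000 nM and compound 3 `COc1ccc(/C=C\c2cc(OC)c(OC)c(OC)c2)cc1OCc1ccc(CN2CCCCC2C(=O)NCCNC(=O)OC(C)(C)C)cc1` gives 48000 nM, two values within the scatter of each other. Compound 2 `COc1ccc(/C=C\c2cc(OC)c(OC)c(OC)c2)cc1OCc1ccc(CN2CCCCC2C(=O)O)cc1` gives > 50000 nM, which is a limit of the assay and not a number. Compound 4 `COc1ccc(/C=C\c2cc(OC)c(OC)c(OC)c2)cc1OCc1ccc(CN2CC(C(=O)O)C2)cc1` differs from compound 2 in one place: 3-carboxyazetidin-1-yl in place of 2-carboxypiperidin-1-yl on a saturated chain carbon bound to an aromatic carbon. Here 3-carboxyazetidin-1-yl stands in place of 2-carboxypiperidin-1-yl, so the carboxylic acid stays while the ring changes. Going by the values given here, two measured steps bear on this change, an at least 1.0-fold higher number from compound 1 to compound 2 (0.03 log units; that floor lies within the scatter) and an at least 1.0-fold lower number from compound 2 to compound 3 (0.01 log units; that floor lies within the scatter), and both lie within the scatter. No step beyond the scatter is therefore expected, and the estimated size is a number no higher from compound 2 to compound 4 (the limit leaves the size open). For compound 4, the estimated value in this assay is 50000 nM, with an expected range of 30000 nM to 100000 nM.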

Compound 4, half-maximal inhibitory concentration: > 50000 nM
Compound 4 was reported as a limit; the forecaster's own chance of this, stated with the estimate: 60%; the middle value lies on the limit itself.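

In this assay, replacing formyl with (3-carboxyazetidin-1-yl)methyl gives an at least 1.0-fold higher number from compound 1 to compound 4 (0.03 log units; that floor lies within the scatter). This shows that a four-membered ring carrying the carboxylic acid, like the six-membered one, produces no step beyond the scatter from compound 1 at this place. Compound 2 and compound 4 cannot be ordered, and the step between them cannot be read, because both are reported only as the same limit of the assay: the limit of > 50000 nM in this assay, at which 2 of the 4 values shown sit.

On these data alone, it remains open whether an amine in place of the carboxylic acid on the four-membered ring would give a measurable value in this assay.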